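A few compounds are considered here, and "the series" means these few. Any claim that something is new, unique, unknown or untested is made for them only; others in the source may bear on it.

In an assay on isolated protein for inhibition of Leucine-rich repeat serine/threonine-protein kinase 2 variant G2019S (Homo sapiens), read by TR-FRET and LanthaScreen, with stated times of 50 min and 30 min, in the presence of a further agent that is not named here (a higher number here means a weaker inhibitor, a lower number a stronger inhibitor), compound 1 `Cn1c(N2CCCC2)c(C#N)c2c(N)ncnc21` gives 1910 nM. Compound 2 `C[C@@H]1CCCN1c1c(C#N)c2c(N)ncnc2n1C` gives 11 nM in this assay, and compound 3 `C[C@H]1CCCN1c1c(C#N)c2c(N)ncnc2n1C` gives 3080 nM. Putting a methyl on a saturated ring carbon produces a 170-fold lower number from compound 1 to compound 2 (2.24 log units; beyond the scatter), whereas the same addition in the other configuration gives a 1.6-fold higher number from compound 1 to compound 3 (0.21 log units; within the scatter). Between the two methylated compounds the gap is a 280-fold higher number from compound 2 to compound 3 (2.45 log units; beyond the scatter), a step that turns on configuration alone, because of the fact that compounds 2 and 3 differ only in the configuration as drawn. Compound 3 thus stands highest of the three numbers, although its gap to compound 1 lies within the scatter, while compound 2 sits far below it.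

Compound 4 `Cn1c(N)c(C#N)c2c(N)ncnc21` arises from compound 3 by the change (amino in place of 2-methylpyrrolidin-1-yl on an aromatic carbon). Among the measured compounds shown here, none of the measured steps removes the saturated ring; each either adds a methyl to it or changes its configuration, so no direct precedent exists for this exchange. What the measured steps do show is that this part of the molecule can move the number a great deal in one configuration and hardly at all in the other. Lacking a precedent, the step of a 1.3-fold higher number from compound 3 to compound 4 (0.11 log units; within the scatter) is expected to be modest and carries a wide uncertainty. Compound 4 is therefore expected to give 4000 nM in this assay, within a range from 800 nM to 20000 nM.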

Compound 4, half-maximal inhibitory concentration: 8560 nM
For compound 4 the middle estimate is 2.1-fold (0.33 log units) below the measured one; measured number inside the range.
By their numbers in this assay, from the lowest: compound 2; then compounds 1 and 3 (each within the scatter of the next); then compound 4.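

Among the compounds shown here, exchanging the saturated ring for amino, a change no earlier step had made, gives a 4.5-fold higher number from compound 1 to compound 4 (0.65 log units; beyond the scatter) in this assay, so at this position on the aromatic carbon even the plain pyrrolidin-1-yl group gives a lower number than amino. Compound 3, whose methyl addition had left the number within the scatter of compound 1, also stands apart from the amino compound, with a 2.8-fold higher number from compound 3 to compound 4 (0.44 log units; beyond the scatter), so the ring in this configuration still retains a modest advantage over amino, whereas the same exchange starting from the other configuration gives a 780-fold higher number from compound 2 to compound 4 (2.89 log units; beyond the scatter) and removes nearly all of the advantage seen in compound 2. The size of this one exchange therefore depends heavily on the configuration of the ring that leaves, as the two starting compounds show: the fact that compounds 2 and 3 differ only in the configuration as drawn.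

The compounds shown leave open how far an open-chain dimethylamino group or a larger piperidin-1-yl ring would bring the number back from that of compound 4, and whether an ethyl in place of the ring methyl would keep the low number of compound 2. They also offer no measured property of amino or 2-methylpyrrolidin-1-yl that could account for these steps.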